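A few compounds are considered here, and "the series" means these few. Any claim that something is new, unique, unknown or untested is made for them only; others in the source may bear on it.

Two compounds were examined in an ADME assay on Vero cells (Chlorocebus sabaeus) for cytotoxicity, read by fluorescence and resazurin assay, with a stated time of 3 days; on this read-out higher numbers stand for lower toxicity in this test and lower numbers for higher toxicity in this test. Compound 1 `CC(=O)C[C@H]1O[C@@H](On2cc(CN3C(=O)/C(=N\Nc4ccc(F)cc4)c4ccccc43)nn2)[C@H](OC(C)=O)[C@@H](OC(C)=O)[C@@H]1OC(C)=O` gives 68700 nM, and compound 2 `COc1ccc(N/N=C2\C(=O)N(Cc3cn(O[C@@H]4O[C@H](CC(C)=O)[C@H](OC(C)=O)[C@H](OC(C)=O)[C@H]4OC(C)=O)nn3)c3ccccc32)cc1` gives 62500 nM in this assay; the two numbers lie within the usual scatter of each other, so neither stands apart. Compound 3 `CC(=O)C[C@H]1O[C@@H](On2cc(CN3C(=O)/C(=N\Nc4ccc(F)cc4)c4ccccc43)nn2)[C@H](OC(C)=O)[C@@H](OC(C)=O)[C@H]1OC(C)=O` is reached from compound 2 by fluoro in place of methoxy on an aromatic carbon. For the measured compounds named here, no measured pair shows this change, and compound 1, which already carries the fluoro group, sits beside compound 2 in this assay. Compound 3 is therefore expected to show no step beyond the scatter, a 1.0-fold higher number from compound 2 to compound 3 (0.02 log units; within the scatter), with an estimated 65000 nM between 35000 nM and 130000 nM.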

Compound 3, half-maximal cytotoxic concentration: 78600 nM
Compound 3: middle estimate off by 1.2-fold (0.08 log units), on the low side, within the range that was stated.
By their numbers in this assay, from the lowest: compounds 2, 1 and 3 (each within the scatter of the next).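

In this assay, for the compounds shown here, the pair of compound 2 and compound 3 gives the first direct reading of fluoro in place of methoxy on an aromatic carbon para to a large group: a 1.3-fold higher number from compound 2 to compound 3 (0.10 log units; within the scatter) stays inside the scatter. Compound 3 also adds a second comparison at a saturated ring carbon, where a 1.1-fold higher number from compound 1 to compound 3 (0.06 log units; within the scatter) likewise stays inside the scatter. That comparison isolates a single stereocentre, and what it rests on is this: the fact that compounds 1 and 3 differ only in the configuration as drawn. Going by these compounds, whether an amine, a carboxylic acid or a longer chain on that aromatic carbon would give a step beyond the scatter remains open. So does the effect of inverting any of the other stereocentres.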